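From hydroxy to amino on compound 1

The source may report more compounds than this note shows. Statements on the series, on what has been measured and on what is new or still open speak of the compounds shown alone.

Two compounds have been measured so far in an ADME assay on HMEC-1 cells (Homo sapiens) for antiproliferative activity (on this read-out lower numbers stand for stronger inhibition and higher numbers for weaker inhibition), with these results:
- Compound 1 `COc1ccc(-c2snnc2-c2cc(OC)c(OC)c(OC)c2)cc1O` gives 3.9 nM
- Compound 2 `COc1cc(-c2nnsc2-c2ccc(F)cc2)cc(OC)c1OC` gives > 1000 nM as a limit of the assay

Going by the values given here, compound 1 has 3.9 nM as the one exact number available in this assay so far, and it is the only reference point for what follows. Compound 2 has > 1000 nM as its reading, which is a limit and not a number.

Compound 3 `COc1ccc(-c2snnc2-c2cc(OC)c(OC)c(OC)c2)cc1N` keeps the core of compound 1 and differs in one place. It carries amino in place of hydroxy on an aromatic carbon, ortho to a methoxy group and meta to a large group, and amino in place of hydroxy on an aromatic carbon gives the full count of that change.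

Among the compounds with values here, no measured pair shows what this exchange does, so the expectation rests on compound 1 at 3.9 nM and on the single-atom size of the change. No step beyond the usual scatter is expected in this assay and the estimate is a 1.8-fold higher number from compound 1 to compound 3 (0.25 log units; within the scatter) for this exchange. Compound 3 is expected at about 7 nM with an estimated range from 2 nM to 40 nM in this read-out.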

Compound 3, half-maximal inhibitory concentration: 2.5 nM
Estimate against measurement, compound 3: 2.8-fold (0.45 log units) above, and the stated range covers the measured number.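

In this assay, amino in place of hydroxy on this aromatic carbon, ortho to a methoxy group and meta to a large group, gives a 1.6-fold lower number from compound 1 to compound 3 (0.19 log units; within the scatter). Going by these compounds alone, compound 1 alone could not show whether hydroxy was the only group at this place compatible with a reading of this order, and this pair shows that amino serves equally well within the scatter of the assay. The exchange leaves the counted hydrogen-bond donors and acceptors unchanged and carries no net charge on either side, and compound 2 stays outside the comparison, as its reading is a limit of the assay and not a number: the limit of > 1000 nM in this assay, at which 1 of the 3 values shown sits.

The compounds shown leave open how a larger or differently built group at this same place would read, such as a dimethylamino group, an acetamido group or a chlorine atom, and thus how far this position tolerates change beyond a swap of one heavy atom. They also leave open whether amino in place of hydroxy would give a comparable step on a core other than that of compound 1.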